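Hydrazone Aryl Swap in a Rat Inhibition Series

The source may hold more compounds than are shown below. What is called first, only, known or untested is meant among the compounds shown, and "the series" means these compounds.

Of the compounds shown here, three have been measured in a functional assay on the whole organism for inhibition, with Rattus norvegicus as the target; a higher number here means that more compound is needed for the effect, a lower number that less compound is needed. Compound 1 `CCOC(=O)c1cnc2n(c1=O)C(C)CC/C2=N\Nc1ccccc1C(=O)O` gives 10 umol/kg. Compound 2 `CC1CC/C(=N\Nc2cccc(Cl)c2)c2ncc(C(=O)O)c(=O)n21` gives 0.6 umol/kg, the second highest of the three numbers; compound 3 `C[C@@H]1CC/C(=N\Nc2ccc(O)cc2)c2ncc(C(=O)O)c(=O)n21` gives 0.14 umol/kg, the lowest of them, and its gap to compound 2 lies beyond the scatter, as does the gap from compound 2 to compound 1. Compound 4 `COc1ccc(N/N=C2\CCC(C)n3c2ncc(C(=O)O)c3=O)cc1` has not yet been measured. It differs from compound 2 in one place: 4-methoxyphenyl in place of 3-chlorophenyl on an amine nitrogen. Among the measured compounds shown here, no single step between measured compounds is available, so the expectation rests on compound 3, whose value of 0.14 umol/kg sits below that of compound 2. For compound 4 a modest downward step is expected, a 2.0-fold lower number from compound 2 to compound 4 (0.30 log units; within the scatter), toward an estimated 0.3 umol/kg, with a range from 0.08 umol/kg to 1.2 umol/kg.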

Compound 4, dose for 50% inhibition: 0.8 umol/kg
Compound 4: the middle estimate sits 2.7-fold (0.43 log units) below what was measured; low and high end bracket the measured number.
By their numbers in this assay, from the lowest: compound 3; then compounds 2 and 4 (each within the scatter of the next); then compound 1.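

In this assay, among the compounds shown here, 4-methoxyphenyl in place of 3-chlorophenyl on the amine nitrogen gives a 1.3-fold higher number from compound 2 to compound 4 (0.12 log units; within the scatter) in the first single change that can be read at this place. The two aryl groups therefore cannot be told apart here, even though the entering group adds a hydrogen-bond acceptor and the leaving group carries chlorine. No measured evidence bears on this result.

Because the chlorine and the methoxy group carry different numbers in their group names, this one step cannot separate the effect of the group from that of where it sits. On these data alone, how an amine or a carboxylic acid on the phenyl ring would compare remains open.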